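A Larger Ring on the Oxygen, Clearance Still Open

A few compounds are considered here, and "the series" means these few. Any claim that something is new, unique, unknown or untested is made for them only; others in the source may bear on it.

In an ADME assay on the whole organism (Rattus norvegicus, strain Sprague-Dawley) for pharmacokinetics, at a dose of 0.5 mg/kg by the intravenous route (on this read-out lower numbers stand for slow clearance and higher numbers for fast clearance), compound 1 (`Cc1cc(Cl)cc(-c2ccnc3cc(CN4C(=O)CCC4=O)sc23)c1O[C@H]1C[C@H](N)C1`) has no number to stand on, its entry being "not determined" (no result reported) and not a measured clearance. Compound 3 (`Cc1cc(Cl)cc(-c2ccnc3cc(CN4C(=O)CCC4=O)sc23)c1O[C@@H]1CCNC[C@@H]1C`) carries 3-methylpiperidin-4-yl in place of 3-aminocyclobutyl on an oxygen on an aromatic ring. Among the compounds with values here, without a starting value, no step can be sized, so none beyond the usual scatter is expected in either direction. Within the data shown here, the only guide is compound 2 (`Cn1nc2c(c1[C@H]1Cc3cc(Cl)cc(-c4ccnc5cc(CN6C(=O)CCC6=O)sc45)c3O1)CNCC2`), which gives 78.3 mL/min/kg in this assay and suggests fast clearance for this small family. Compound 3 is therefore expected at 65 mL/min/kg (estimated range 30 mL/min/kg to 110 mL/min/kg).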

Compound 3, clearance: 1.17 mL/min/kg
For compound 3 the middle estimate is 56-fold (1.74 log units) above the measured one; the measured number lies below the stated range.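

Within the data shown here, compound 1 has no number to set against compound 3 in this assay, so no step between them can be read. The compounds shown leave open what 3-methylpiperidin-4-yl in place of 3-aminocyclobutyl does to clearance, and no data here offer an explanation.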